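The source may report more compounds than this note shows. Statements on the series, on what has been measured and on what is new or still open speak of the compounds shown alone.

Measured compounds in the series:

compound 1, `N#Cc1cc(-c2nc3ccc(F)cc3s2)ccc1N`: 320 nM
compound 2, `C[Si](C)(C)C#Cc1cc(-c2nc3ccc(F)cc3s2)ccc1N`: 400 nM
compound 3, `N#Cc1cc(-c2nc3ccccc3s2)ccc1N`: 340 nM

All three numbers come from a functional assay on MDA-MB-468 cells (Homo sapiens) for inhibition, with a stated time of 72 h; a higher number here means a weaker inhibitor of growth, a lower number a stronger inhibitor of growth. In this assay compound 1 gives 320 nM, compound 2 gives 400 nM and compound 3 gives 340 nM; none of the pairs is separated by more than the usual scatter.

Two single-point changes connect the measured set. From compound 1 to compound 2 the change is a group of 6 heavy atoms (5 carbon, 1 silicon; no ring) in place of a group of 2 heavy atoms (1 carbon, 1 nitrogen; no ring), on an aromatic carbon, and it made a 1.3-fold higher number from compound 1 to compound 2 (0.10 log units; within the scatter). From compound 1 to compound 3 the change is hydrogen in place of fluoro on an aromatic carbon, and it made a 1.1-fold higher number from compound 1 to compound 3 (0.03 log units; within the scatter). Compound 2 and compound 3 differ in two places at once; their two values lie close together.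

Compound 4, `C[Si](C)(C)C#Cc1cc(-c2nc3ccccc3s2)ccc1N`, has not yet been measured. It differs from compound 3 by a group of 6 heavy atoms (5 carbon, 1 silicon; no ring) in place of a group of 2 heavy atoms (1 carbon, 1 nitrogen; no ring), on an aromatic carbon. Among the compounds with values here, this is the same kind of change as the one from compound 1 to compound 2, not the same change: the two cores on which it is made differ by hydrogen in place of fluoro on an aromatic carbon.

For compound 4 in this assay the expected step is a 1.2-fold higher number from compound 3 to compound 4 (0.09 log units; within the scatter), set beside the earlier 1.3-fold higher number from compound 1 to compound 2 (0.10 log units; within the scatter), because the same kind of change on compound 1 gave a 1.3-fold higher number from compound 1 to compound 2 (0.10 log units; within the scatter) and the core change gave a 1.1-fold higher number from compound 1 to compound 3 (0.03 log units; within the scatter), both small. The estimate for compound 4 in this assay is therefore 420 nM, expected to fall between 210 nM and 850 nM.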

Compound 4, concentration for 50% growth inhibition: 560 nM
The estimate for compound 4 lay 1.3-fold (0.12 log units) below the measured number; the range from low to high includes it.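

In this assay, putting the group of 6 heavy atoms (5 carbon, 1 silicon) in place of cyano gives a 1.6-fold higher number from compound 3 to compound 4 (0.22 log units; within the scatter), and the step carries from the core of compound 1 to the core of compound 3 with no difference that can be told apart: the same change on two cores in this assay, a 1.3-fold higher number (0.10 log units; within the scatter) from compound 1 to compound 2 and a 1.6-fold higher number (0.22 log units; within the scatter) from compound 3 to compound 4, 1.3-fold (0.12 log units) apart, within the scatter of two such steps

Hydrogen in place of fluoro, read with the silicon-containing group present, gives a 1.4-fold higher number from compound 2 to compound 4 (0.15 log units; within the scatter), and this step likewise agrees with its earlier counterpart: the same change on two cores in this assay, a 1.1-fold higher number (0.03 log units; within the scatter) from compound 1 to compound 3 and a 1.4-fold higher number (0.15 log units; within the scatter) from compound 2 to compound 4, 1.3-fold (0.12 log units) apart, within the scatter of two such steps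

The four compounds therefore give no sign that either change depends on the other, but every step lies within the scatter, so a small dependence would stay hidden, and the result covers this one pair of cores and this one cell line only.

Open, as far as these compounds go, is whether the agreement would survive on the same aromatic carbon with a carboxylic acid, a primary amide or a longer alkyl chain in place of cyano, where steps might be large enough to compare with confidence. Also open, from the compounds shown here alone, is whether chloro or methoxy in place of fluoro would behave the same way on the shared core.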